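Swapping the Aryl Ether for a Fluorophenyl Thioether

This account rests on a few compounds, and the source may have more. Where it says the series, first, only, none or still open, it means among the compounds named here.

Compound 1 `Nc1cc(N)c2nc(-c3ccccc3)c(Oc3ccc(Cl)c(Cl)c3)nc2c1` was examined in a functional assay on HOP-62 cells (Homo sapiens) for inhibition, read by sulforhodamine B assay, with a stated time of 48 h (on this read-out lower numbers stand for higher toxicity in this test and higher numbers for lower toxicity in this test), where compound 1 gives 85100 nM. Compound 2 `Nc1cc(N)c2nc(-c3ccccc3)c(NCc3ccc(Cl)c(Cl)c3)nc2c1` gives 64600 nM in this assay; these two numbers lie within the scatter of each other, so compound 1 cannot be set apart from compound 2 on this read-out. For compound 3 `CCOC(=O)[C@H](CCC(=O)O)NC(=O)c1ccc(Sc2nc3cc(N)cc(N)c3nc2-c2ccccc2)cc1` the this assay reports only a limit, < 100000 nM. That limit is the one exception among the three values: the limit of < 100000 nM in this assay, at which 1 of the 3 values shown sits.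

Compound 4 `Nc1cc(N)c2nc(-c3ccccc3)c(Sc3ccc(F)cc3)nc2c1` has not yet been measured in this assay. It differs from compound 1 in one place: (4-fluorophenyl)sulfanyl in place of 3,4-dichlorophenoxy on an aromatic carbon. No change between two measured compounds is available to gauge the size of such a replacement, and the two numbers that do exist sit close together in a weakly toxic region. The step of a 1.2-fold lower number from compound 1 to compound 4 (0.08 log units; within the scatter) is therefore expected to stay within the scatter, in no particular direction. Compound 4 is estimated at 70000 nM, expected to fall between 25000 nM and 150000 nM.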

Compound 4, concentration lethal to 50% of the cells: 70800 nM
The estimate for compound 4 lay 1.0-fold (0.00 log units) below the measured number; the range from low to high includes it.
By their numbers in this assay, from the lowest: compounds 2, 4 and 1 (each within the scatter of the next).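

In this assay, among the compounds shown here, placing (4-fluorophenyl)sulfanyl in place of 3,4-dichlorophenoxy gives a 1.2-fold lower number from compound 1 to compound 4 (0.08 log units; within the scatter), the first step that can be read at this position next to the ring nitrogen. The number therefore does not separate the two groups, even though the exchange alters both the linking atom and the substituents on the aromatic ring. Compound 3 remains the one compound with a limit rather than a number: the limit of < 100000 nM in this assay, at which 1 of the 4 values shown sits.

As the two alterations occur together in a single step, the contribution of each cannot be read. Going by these compounds, it also remains open whether a piperazine or a longer alkyl chain on this aromatic carbon would move the number beyond the scatter, or whether the read-out stays unchanged across more distant replacements as well.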